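A few compounds are considered here, and "the series" means these few. Any claim that something is new, unique, unknown or untested is made for them only; others in the source may bear on it.

Of the compounds shown here, two have been read so far in an ADME assay on Vero cells (Chlorocebus sabaeus) for cytotoxicity, read by resazurin assay, with a stated time of 72 h; on this read-out higher numbers stand for weaker inhibition and lower numbers for stronger inhibition. Compound 1 (`COc1ccc(C(=O)CCN2CCN(c3ccc(Cl)cc3)CC2)cc1`) gives 300000 nM, and compound 2 (`O=C(CCN1CCN(c2ccc(C(F)(F)F)cc2)CC1)c1ccc(Cl)c(F)c1`) gives 74300 nM, the lower number of the two, with the gap beyond the scatter. Compound 3 (`O=C(CCN1CCN(c2ccc(Cl)cc2)CC1)c1ccc(Cl)c(F)c1`) departs from compound 2 in one place: chloro in place of trifluoromethyl on an aromatic carbon. Within the data shown here, no measured pair isolates this change, so the expectation rests on thin evidence. Compound 1 also bears chloro at that place and gives 300000 nM, but it differs from compound 3 elsewhere as well. A small move toward a higher number, meaning weaker inhibition, is therefore expected. The estimated step is a 1.3-fold higher number from compound 2 to compound 3 (0.13 log units; within the scatter), which is not expected to lie beyond the scatter. For compound 3 the estimated value is 100000 nM, with an expected range of 45000 nM to 230000 nM.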

Compound 3, half-maximal inhibitory concentration: 175000 nM
Beside the measured number, compound 3's estimate is 1.8-fold (0.24 log units) below it; the range from low to high includes it.
By their numbers in this assay, from the lowest: compound 2; then compounds 3 and 1 (each within the scatter of the next).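

In this assay the place para to a large group now has its first pair that differs only there: chloro in place of trifluoromethyl on an aromatic carbon gives a 2.4-fold higher number from compound 2 to compound 3 (0.37 log units; beyond the scatter) and so shows that this one exchange can move the read-out past the scatter, though only by a modest step. With chloro held at that place, 4-chloro-3-fluorophenyl in place of 4-methoxyphenyl on a carbonyl carbon gives a 1.7-fold lower number from compound 1 to compound 3 (0.23 log units; within the scatter) and so this second exchange is not resolved in this assay. No measurement on hand offers an explanation for the step at the aromatic carbon.

From the compounds shown here alone, whether the step at this place holds with 4-methoxyphenyl on the carbonyl carbon remains open, as a single pair supports it. Also open, going by these compounds, is how a nitrile, a bromo group or a plain hydrogen would read at this place, and how a longer chain on the carbonyl carbon would read.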